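Pyrimidinyl for furanyl on an imidazolylmethyl biphenyl scaffold

The compounds below may be only part of what the source reports. "The series", "measured", "known", "first", "only" and "open" are said of these compounds alone.

Measured compounds:
Compound 1 `c1cn(Cc2ccc(-c3ccoc3)cc2)cn1`: 3%
Compound 2 `CSc1ccc(-c2ccc(Cn3ccnc3)cc2)s1`: 3%
Compound 3 `CCC(c1cc(-c2ccc(F)c(F)c2)cs1)n1ccnc1`: 17%

In an assay for inhibition of steroid 17-alpha-hydroxylase/17,20 lyase (Homo sapiens), using NADPH, tested at 0.2 uM (a lower number here means a weaker effect, a higher number a stronger effect of the compound at the concentration tested), compound 1 gives 3%. Compound 2 gives a reading that matches compound 1 at the digits shown, so the two cannot be told apart within the usual scatter. Compound 3, with a different core, gives 17%, a reading that lies beyond the scatter above compound 1. Nothing among these three compounds isolates the contribution of the furan-3-yl group of compound 1, since no pair differs in one place only.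

Compound 4 `c1cn(Cc2ccc(-c3cncnc3)cc2)cn1` has not yet been tested. It differs from compound 1 as follows: pyrimidin-5-yl in place of furan-3-yl on an aromatic carbon. The place is the same, the entering ring is six-membered where the leaving ring was five-membered, and the count of acceptors rises by one. Because compound 1 gives 3% and compound 2 sits at the same level, the expected step of a number 3 percentage points higher from compound 1 to compound 4 (within the scatter) is small, likely within the scatter, with a slight lean upward. Compound 4 is therefore estimated at 6%, in a range from 0% to 20%.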

Compound 4, a percentage reported as inhibition, at one concentration (the size of the read-out at that concentration, not a potency): 5%
Estimate against measurement, compound 4: 1 percentage points above, within the range that was stated.
By their numbers in this assay, from the lowest: compounds 1, 2 and 4 (each within the scatter of the next); then compound 3.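

In this assay, for the compounds shown here, the exchange of furan-3-yl for pyrimidin-5-yl on the aromatic carbon gives a number 2 percentage points higher from compound 1 to compound 4 (within the scatter), the first one-place comparison in this set. At this position, the six-membered aromatic ring with 2 hetero atoms therefore cannot be told apart from the five-membered aromatic ring with 1 hetero atom, and the added hydrogen-bond acceptor brings no difference that this read-out can resolve. Nothing measured here offers a reason for this outcome.

Going by these compounds, it remains open how a group of another kind, such as a carboxylic acid, a primary amine or a morpholine ring, would read at this position. It is also open whether the same exchange would read alike on a different core, as only one pair carrying it is shown.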